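Urea substituent swap on a spirocyclic T-type channel inhibitor

A few compounds are considered here, and "the series" means these few. Any claim that something is new, unique, unknown or untested is made for them only; others in the source may bear on it.

Of the compounds shown here, two have been measured in an assay on HEK293 cells for inhibition of Voltage-dependent T-type calcium channel subunit alpha-1H (Homo sapiens), read by patch clamp, using a membrane potential dye; a higher number here means a weaker inhibitor, a lower number a stronger inhibitor. Compound 1 `CC(C)N1CC2(CCN(C(=O)Nc3cc(F)cc(F)c3)CC2)C1c1ccc(F)cc1` gives 172 nM in this assay. Compound 2 `CC[C@H](C)[C@H](NC(=O)N1CCC2(CC1)C(=O)N(c1cccc(F)c1)C2c1ccc(Cl)cc1)C(=O)NC`, which carries a spiro-lactam core with a fluorophenyl on the lactam nitrogen and a chlorophenyl on the adjacent carbon, gives 182 nM in this assay; its number and that of compound 1 lie within the usual scatter of one another, so the two cannot be separated on potency.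

Compound 3 `C[C@H](NC(=O)N1CCC2(CC1)C(=O)N(c1cccc(F)c1)C2c1ccc(Cl)cc1)c1ccccc1` is not yet measured. It differs from compound 2 in one place: 1-phenylethyl in place of 2-methyl-1-(methylcarbamoyl)butyl on an amide-type nitrogen. The group that leaves brings a hydrogen-bond donor and an acceptor and two defined stereocentres; the group that enters is a carbon-only aromatic ring with a single stereocentre and no donor or acceptor. For the measured compounds named here, no measured pair in this set shows the effect of such an exchange on this assay, so there is no step to lean on.

With nothing to suggest a direction, the step from compound 2 to compound 3 is expected to stay within the scatter, a 1.2-fold lower number from compound 2 to compound 3 (0.08 log units; within the scatter). Compound 3 is therefore estimated to give about 150 nM in this assay, within a range of 40 nM to 600 nM.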

Compound 3, half-maximal inhibitory concentration: 139 nM
Compound 3: middle estimate off by 1.1-fold (0.03 log units), on the high side, within the range that was stated.
By their numbers in this assay, from the lowest: compounds 3, 1 and 2 (each within the scatter of the next).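

For the compounds shown here, on the amide-type nitrogen, the exchange of 2-methyl-1-(methylcarbamoyl)butyl for 1-phenylethyl gives the first single-place comparison: a 1.3-fold lower number from compound 2 to compound 3 (0.12 log units; within the scatter) in this assay. At this position, then, a group with a hydrogen-bond donor, a hydrogen-bond acceptor and two defined stereocentres gives way to a carbon-only aromatic group with a single stereocentre, and the step stays within the scatter. Nothing at hand bears on why the two numbers stay so close.

What the compounds shown leave open is how far this tolerance extends, as they give no reading for a benzyl or cyclohexyl group at this nitrogen, or for a side chain ending in a carboxylic acid or an amine. They also leave open whether the opposite stereoisomer of 1-phenylethyl would read the same as compound 3, and whether the fluorophenyl and chlorophenyl groups of the shared core matter to the number in this assay.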